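This account rests on a few compounds, and the source may have more. Where it says the series, first, only, none or still open, it means among the compounds named here.

Measured so far:
- In an assay on membranes from HeLa cells for displacement of a labelled ligand from adenosine receptor A3 (Homo sapiens), read by scintillation counting, with a stated time of 180 min, tested at 1 uM (a lower number here means less inhibition, a higher number more inhibition at the concentration tested (going by the name of the read-out)), compound 1 `CCNC(=O)C1=C(C)NC(=O)NC1c1ccsc1` gives 1%.
- In this assay compound 2 `CC1=C(C(=O)NC(C)C)C(c2ccsc2)NC(=O)N1` gives 1%.
- In this assay compound 3 `CCC(CC)OC(=O)C1=C(C)NC(=O)NC1c1ccco1` gives 1%.

All three measured compounds sit at the same level within the scatter; none stands apart from the others. Compound 1 and compound 2 share a core, whereas compound 3 rests on another core, and the difference between the two cores is not broken down here. From compound 2 to compound 1 the change is hydrogen in place of methyl on a saturated chain carbon bound to an amide-type nitrogen and a saturated chain carbon, and the step is no change at the digits printed from compound 2 to compound 1 (within the scatter).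

Compound 4 `CCC(C)OC(=O)C1=C(C)NC(=O)NC1c1ccco1` has not yet been measured. It is reached from compound 3 by hydrogen in place of methyl on a saturated chain carbon, two bonds along the chain from an oxygen next to a carbonyl group. This is the same kind of change as that from compound 2 to compound 1, not the same: there the place was on a saturated chain carbon bound to an amide-type nitrogen and a saturated chain carbon, here it is on a saturated chain carbon, two bonds along the chain from an oxygen next to a carbonyl group.

Because the earlier step of no change at the digits printed from compound 2 to compound 1 (within the scatter) was flat, and because compound 3 itself gives 1%, the step of no change at the digits printed from compound 3 to compound 4 (within the scatter) is expected to be flat as well. Compound 4 is accordingly estimated at 1% in this assay, with the expected range running from 0% to 8%.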

Compound 4, a percentage reported as inhibition, at one concentration (the size of the read-out at that concentration, not a potency): 3%
For compound 4 the middle estimate is 2 percentage points below the measured one, within the range that was stated.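

In this assay the new step is a number 2 percentage points higher from compound 3 to compound 4 (within the scatter). Set beside the earlier step, hydrogen in place of methyl carries from one core to the other with no difference that can be told apart: the same change on two cores in this assay, no change at the digits printed (within the scatter) from compound 2 to compound 1 and a number 2 percentage points higher (within the scatter) from compound 3 to compound 4, 2 percentage points apart, within the scatter of two such steps. Among the compounds shown here, this shows only that the change stays flat on both cores at a level of very little inhibition at the single concentration tested; it does not show that the change would keep its size on a compound with a clearly larger read-out, and the two places are of the same kind but not identical, one on a carbon bound to an amide-type nitrogen, the other two bonds along the chain from an oxygen next to a carbonyl group.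

Still open, on these data alone, is whether a longer chain, an amine or a carboxylic acid on the ester or amide side would move the read-out away from this level. Also open, as far as these compounds go, is whether a step of this kind would remain flat on any compound that shows a clear read-out.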